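A few compounds are considered here, and "the series" means these few. Any claim that something is new, unique, unknown or untested is made for them only; others in the source may bear on it.

Measured compounds:
- compound 1, `CCOc1cccc(-c2ccc(CN(C(=O)C3CCCCC3)c3cccc(/C=C/C(=O)OC)c3)cc2)c1`: 147 nM
- compound 2, `CCOc1cccc(-c2ccc(CN(C(=O)C(C)C)c3cccc(/C=C/C(=O)OC)c3)cc2)c1`: 173 nM
- compound 3, `COC(=O)/C=C/c1cccc(N(Cc2ccc(-c3ccc(N(C)C)cc3)cc2)C(=O)NC(C)C)c1`: 162 nM

All three were tested in an assay on isolated protein with Bile acid receptor (Homo sapiens) as the target; a higher number here means that more compound is needed for the effect, a lower number that less compound is needed. Compound 1 gives the lowest of the three numbers, but its gap to compound 3 and to compound 2 falls within the usual scatter, so none of the three can be set apart from the others. For the measured compounds named here, the one step that can be read on its own, a 1.2-fold higher number from compound 1 to compound 2 (0.07 log units; within the scatter), concerns a change on a carbonyl carbon and is also within the scatter.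

The unmeasured compound 4, `COC(=O)/C=C/c1cccc(N(Cc2ccc(/C=C/C(=O)OCc3ccccc3)cc2)C(=O)C2CCCCC2)c1`, differs from compound 1 at another place: 2-(benzyloxycarbonyl)ethenyl in place of 3-ethoxyphenyl on an aromatic carbon. Going by the values given here, no measured pair shows this exchange or anything close to it, and compound 3 differs from compound 1 in several places at once, so its value says nothing about this single change. On these data alone, the expectation therefore rests only on the fact that the compounds seen so far sit close together: compound 4 is expected to land near them, with a wide range because the change itself is untested, giving an expected step of a 1.7-fold higher number from compound 1 to compound 4 (0.23 log units; within the scatter). The estimate for compound 4 in this assay is 250 nM, with a range from 70 nM to 900 nM.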

Compound 4, half-maximal effective concentration: > 1000 nM
Compound 4 was reported as a limit; the forecaster's own chance of this, stated with the estimate: 5%; middle value at least 4.0-fold (0.60 log units) away from the limit.
By their numbers in this assay, from the lowest: compounds 1, 3 and 2 (each within the scatter of the next). At a limit, above all of these: compound 4.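

Compound 4 gives > 1000 nM in this assay, and this value is a limit of the assay, not a number. For the compounds shown here, the step, an at least 6.8-fold higher number from compound 1 to compound 4 (0.83 log units; beyond the scatter), is the first one here that lies beyond the scatter, so this aromatic carbon, para to a large group, is a place where the choice of group clearly changes the read-out, whereas the exchange on the carbonyl carbon gave no readable change. How large the step really is stays unknown: the limit of > 1000 nM in this assay, at which 1 of the 4 values shown sits.

The two groups differ in more than one way, since the entering one has an ethenyl link and a benzyl ester, and a single exchange cannot show which of these features counts. Also open, on these data alone, is how a carboxylic acid at the end of the ethenyl chain, or a small amine on this aromatic carbon, would read in this assay.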